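From tert-butyl to methoxycarbonyl on a shared core

The source may hold more compounds than are shown below. What is called first, only, known or untested is meant among the compounds shown, and "the series" means these compounds.

In an ADME assay on HEK293 cells (Homo sapiens) for cytotoxicity, with a stated time of 72 h (a higher number here means that more compound is needed for the effect, a lower number that less compound is needed), two compounds on a shared core have been measured so far. Compound 1 `Cc1cc(NC(=O)Nc2ccc(C(C)(C)C)cc2)c2ccccc2n1` gives > 25000 nM as a limit of the assay, not a number. Compound 2 `COc1ccc(NC(=O)Nc2cc(C)nc3ccccc23)cc1OC` gives > 25000 nM and this too is a limit. Compound 1 therefore has no exact value and stands, along with compound 2, at the limit of > 25000 nM in this assay, at which 2 of the 2 values shown sit, so far.

Compound 3 `COC(=O)c1ccc(NC(=O)Nc2cc(C)nc3ccccc23)cc1` has not yet been measured. It keeps the core of compound 1 and differs in one place, with methoxycarbonyl in place of tert-butyl on an aromatic carbon, para to a large group methoxycarbonyl in place of tert-butyl on an aromatic carbon being the whole change. Among the compounds with values here, no measured step shows what such a swap does. Within the data shown here, on the ground of the limit of > 25000 nM in this assay, at which 2 of the 2 values shown sit, as the only evidence, no step beyond the scatter is expected in this assay for this swap, and the estimated step is a number no higher from compound 1 to compound 3 (the limit leaves the size open) at its centre. Compound 3 is expected at about 25000 nM with an estimated range from 10000 nM to 50000 nM as its span.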

Compound 3, half-maximal effective concentration: 15000 nM
For compound 3 the middle estimate is 1.7-fold (0.22 log units) above the measured one; the range from low to high includes it.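

In this assay, within the data shown here, compound 3 is the first compound on the shared core to give an exact number rather than a limit, so methoxycarbonyl on this aromatic carbon, para to a large group, brings the value within the range the assay can read. The change gives an at least 1.6-fold lower number from compound 1 to compound 3 (0.22 log units; that floor lies within the scatter), and as that step starts from a limit, only its floor is known and not its true size. Most of what is known in this assay is still a boundary rather than a number: the limit of > 25000 nM in this assay, at which 2 of the 3 values shown sit.

The compounds shown leave open how large the real gap between tert-butyl and methoxycarbonyl is, as compound 1 carries only a limit and the floor of the step does not clear the usual scatter. They also leave open what a carboxylic acid, an amine or a longer chain on this same aromatic carbon would give, and so whether the number seen for compound 3 belongs to methoxycarbonyl alone or would also appear with other groups here.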